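Methyl Added to Compound 2

The source may hold more compounds than are shown below. What is called first, only, known or untested is meant among the compounds shown, and "the series" means these compounds.

Measured compounds:
Compound 1, `CCc1ccc(OC)c(COc2ccc(Cl)c(C)c2)c1`, gives 43000 nM.
Compound 2, `COc1ccc(C(N)=O)cc1/C=C/c1ccccc1`, gives 36000 nM.

Both compounds were tested in an ADME assay on HCT-116 cells (Homo sapiens) for antiproliferative activity; a lower number here means a stronger inhibitor, a higher number a weaker inhibitor. Compound 2 shows the lower of the two numbers, but compound 1 sits only a small distance away, and the gap between them lies within the usual scatter of such measurements, so the two cannot be ranked against each other on these data alone.

The next compound is compound 3, `COc1ccc(C(N)=O)cc1/C=C/c1ccc(C)cc1`. It differs from compound 2 in a single place: methyl in place of hydrogen on an aromatic carbon. The benzamide and methoxy side of the molecule is unchanged, and only the distant aromatic ring carries the new group.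

For the measured compounds named here, no measured pair in this small set shows what such an exchange does, so the expectation rests on the size of the change alone. A methyl in place of hydrogen on an aromatic carbon is a small addition, and the step of a 1.3-fold lower number from compound 2 to compound 3 (0.11 log units; within the scatter) is expected to stay within the scatter or to fall only slightly below it. Compound 3 is therefore estimated at 28000 nM, within the range 9000 nM to 80000 nM.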

Compound 3, half-maximal inhibitory concentration: 48000 nM
Compound 3: the middle estimate sits 1.7-fold (0.23 log units) below what was measured; the range from low to high includes it.
By their numbers in this assay, from the lowest: compounds 2, 1 and 3 (each within the scatter of the next).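

In this assay, for the compounds shown here, the exchange of hydrogen for methyl on an aromatic carbon, para to a large group, gives a 1.3-fold higher number from compound 2 to compound 3 (0.12 log units; within the scatter) and so provides the first comparison in this set of compounds that differ in one place. At this position on the ring of carbon only, the added methyl produces no difference that can be told from the scatter, and compound 2 and compound 3 cannot be ranked against each other on these numbers. Nothing available bears on why this single exchange leaves the read-out within the scatter.

What the compounds shown leave open is whether this position responds to anything other than methyl, such as a chlorine atom, a methoxy group, an amine, a carboxylic acid or a longer chain like ethyl or propyl. They also leave open whether the same methyl placed on another carbon of that ring, or on the benzamide and methoxy side of the molecule, would stay within the scatter as it does here.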